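Methyl to nitro on the aromatic ring of compound 3

The compounds below may be only part of what the source reports. "The series", "measured", "known", "first", "only" and "open" are said of these compounds alone.

In an ADME assay on PANC-1 cells (Homo sapiens) for cytotoxicity, read by MTT assay (a higher number here means that more compound is tolerated, a lower number that less compound is tolerated), compound 3 (`Cc1ccccc1-c1nnc(-c2sc(-c3cccnc3)nc2C)o1`) gives > 100 ug/mL as a limit and not a number. Compound 1 (`Cc1nc(-c2cccnc2)sc1-c1nnc(-c2ccccc2Cl)o1`) gives > 100 ug/mL as a limit too. Compound 2 (`Cc1nc(-c2cccnc2)sc1-c1nnc(-c2ccccc2)o1`) likewise gives > 100 ug/mL as a limit. Compound 4 (`Cc1nc(-c2cccnc2)sc1-c1nnc(-c2ccccc2[N+](=O)[O-])o1`) carries nitro in place of methyl on an aromatic carbon, ortho to a large group: nitro in place of methyl on an aromatic carbon. On these data alone, the same place changes in a step that the two limits leave unreadable from compound 1 to compound 2 and in a step that the two limits leave unreadable from compound 1 to compound 3 and in a step that the two limits leave unreadable from compound 2 to compound 3, so no size or direction can be read, and nitro itself is untested. No step beyond the scatter is expected, and a number no higher from compound 3 to compound 4 (the limit leaves the size open) is the step expected. Compound 4 is estimated at 100 ug/mL with an expected range of 50 ug/mL to 200 ug/mL and may again return only a limit.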

Compound 4, half-maximal cytotoxic concentration: > 100 ug/mL
Compound 4 ended at the assay's limit (the forecaster's own chance of this, stated with the estimate: 75%); the middle value lies on the limit itself.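

No step can be read among compounds 1, 2, 3 and 4, which all stop at a limit and give no number in this assay: the limit of > 100 ug/mL in this assay, at which 4 of the 4 values shown sit. The compounds shown leave open whether hydrogen, chloro, methyl and nitro on this aromatic carbon differ at all.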